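The source may hold more compounds than are shown below. What is called first, only, known or untested is meant among the compounds shown, and "the series" means these compounds.

Compound 1 `C[C@@H](CO)Nc1nc(C(=O)NCc2ccc(F)cc2)c(O)c2ncccc12` carries no result in a functional assay on HCT-116 cells (Homo sapiens) for cytotoxicity, read by MTT assay, with a stated time of 72 h; on this read-out lower numbers stand for stronger inhibition and higher numbers for weaker inhibition: its entry there is "not determined" (no result reported), so nothing can be said of it there. Compound 2 `CS(=O)(=O)Oc1c(C(=O)NCc2ccc(F)cc2)nc(Br)c2cccnc12` stands at the edge of what this assay measures: its entry, > 20000 nM, is a limit rather than a number, and it sits at the limit of > 20000 nM in this assay, at which 1 of the 2 values shown sits. Compound 3 `NCCNc1c(C(=O)NCc2ccc(F)cc2)nc(Br)c2cccnc12` has not yet been measured, and it differs from compound 2 in one place, ((2-aminoethyl)amino in place of (methylsulfonyl)oxy on an aromatic carbon). For the measured compounds named here, no step between two measured compounds is known, so there is nothing to set the size of this change against. Given that compound 2 reaches only a limit, the step from compound 2 to compound 3 is expected to be small or absent beyond the scatter, with the outcome for compound 3 estimated at an at least 2.0-fold lower number from compound 2 to compound 3 (0.30 log units; that floor lies within the scatter). Compound 3 is therefore expected to give about 10000 nM, within a range from 2500 nM to 40000 nM.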

Compound 3, half-maximal inhibitory concentration: > 20000 nM
Compound 3 gave a limit, no number (the forecaster's own chance of this, stated with the estimate: 50%); at least 2.0-fold (0.30 log units) between middle value and limit.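

In this assay compound 3 gives > 20000 nM, which is a limit and not a number. For the compounds shown here, compound 2 also stands at a limit, so no step between compound 2 and compound 3 can be read: the limit of > 20000 nM in this assay, at which 2 of the 3 values shown sit. The compounds shown leave open how (2-aminoethyl)amino and (methylsulfonyl)oxy compare in this assay, and whether the shared core can give a number there at all.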